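Swapping the aryl group on a sulfonamide chain

The source may report more compounds than this note shows. Statements on the series, on what has been measured and on what is new or still open speak of the compounds shown alone.

Compound 1 `CC(C)(C)c1ccc(CNCCCNS(=O)(=O)c2cc(C(F)(F)F)cc(C(F)(F)F)c2)cc1` gives 3200 nM in a toxicity assay on MCF-10A cells (Homo sapiens) for inhibition, read by MTT assay, with a stated time of 72 h (on this read-out lower numbers stand for stronger inhibition of growth and higher numbers for weaker inhibition of growth), nominally the higher of the two measured numbers, though the gap to compound 2 lies within the scatter. Compound 2 `O=S(=O)(NCCCNCc1ccc(Cl)c(Cl)c1)c1cc(C(F)(F)F)cc(C(F)(F)F)c1` gives 3000 nM in this assay, and the step of a 1.1-fold lower number from compound 1 to compound 2 (0.03 log units; within the scatter) shows no real shift. Compound 3 `O=S(=O)(NCCCNCc1cccc(Cl)c1)c1cc(C(F)(F)F)cc(C(F)(F)F)c1` differs from compound 1 by 3-chlorophenyl in place of 4-(tert-butyl)phenyl on a saturated chain carbon bound to an amine nitrogen. Among the compounds with values here, only that one step bears on this change, and it was within the scatter, so no step beyond the scatter is expected. Compound 3 is expected to give 3000 nM. The estimated range for compound 3 runs from 1500 nM to 6500 nM. The expected step is a 1.1-fold lower number from compound 1 to compound 3 (0.03 log units; within the scatter).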

Compound 3, concentration for 50% growth inhibition: 7000 nM
Estimate against measurement, compound 3: 2.3-fold (0.37 log units) below, outside the stated range (above it).
By their numbers in this assay, from the lowest: compounds 2 and 1 (each within the scatter of the next); then compound 3.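

This position is not indifferent to the aryl group, even though the first swap suggested it might be. In this assay, 3-chlorophenyl in place of 4-(tert-butyl)phenyl gives a 2.2-fold higher number from compound 1 to compound 3 (0.34 log units; beyond the scatter), and hydrogen in place of chloro on an aromatic carbon gives a 2.3-fold higher number from compound 2 to compound 3 (0.37 log units; beyond the scatter), both modest but beyond the scatter. Nothing available here explains these steps. From the compounds shown here alone, it remains open whether an amine or a carboxylic acid in place of the chloro would move the number further, and whether a longer chain would change the picture.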